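The compounds below may be only part of what the source reports. "The series", "measured", "known", "first", "only" and "open" are said of these compounds alone.

Working notes on the series. Compound 1 `Cc1cc(Oc2ccc(CC3SC(=O)NC3=O)cc2)nc(C(F)(F)F)c1` and compound 2 `Cc1ccnc(Oc2ccc(CC3SC(=O)NC3=O)cc2)c1` share one core and differ only on the pyridine ring. In a functional assay for agonist activity at Free fatty acid receptor 1 (Homo sapiens), read by FLIPR, in the presence of a further agent that is not named here (on this read-out lower numbers stand for an effect already at smaller amounts and higher numbers for an effect only at larger amounts of compound), compound 1 gives 688 nM, and in this assay compound 2 gives 4280 nM. Going by the values given here, the single measured step, a 6.2-fold higher number from compound 1 to compound 2 (0.79 log units; beyond the scatter), is the only movement seen so far. Compound 2 thus stands at the highest number of the two measured, with compound 1 as its nearest neighbour at a lower number.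

Compound 3 `O=C1NC(=O)C(Cc2ccc(Oc3cccc(Cl)c3)cc2)S1` differs from compound 2 by 3-chlorophenyl in place of 4-methylpyridin-2-yl on an oxygen on an aromatic ring. Among the compounds with values here, no measured step touches this exchange of the whole ring; the one step seen, from compound 1 to compound 2, only shows that a change on that ring can shift this assay by a modest amount. With nothing closer to lean on, a step of about that size in either direction is possible, and a middle expectation near the value of compound 2 is taken. For compound 3 the expected step is a 1.7-fold lower number from compound 2 to compound 3 (0.23 log units; within the scatter). Compound 3 is estimated at 2500 nM in this assay, within a range from 600 nM to 10000 nM.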

Compound 3, half-maximal effective concentration: 318 nM
Compound 3: the middle estimate sits 7.9-fold (0.90 log units) above what was measured, and the stated range ends above it.
By their numbers in this assay, from the lowest: compound 3; then compound 1; then compound 2.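

Going by these compounds alone, the exchange of 4-methylpyridin-2-yl for 3-chlorophenyl on the oxygen gives, in this assay, a 13-fold lower number from compound 2 to compound 3 (1.13 log units; beyond the scatter), a step printed as large, whereas the only earlier step, a 6.2-fold higher number from compound 1 to compound 2 (0.79 log units; beyond the scatter), was printed as modest and came from a hydrogen replacing trifluoromethyl on the ring. This shows that the group on the oxygen can be replaced as a whole, by a ring of carbon only, and that the number then falls rather than rises, which a single change of substituent on the pyridine ring could not show. Nothing at hand gives a reason for this shift.

The exchange removes the ring nitrogen and the methyl and brings in chlorine in one step, so the share of each in the change remains unresolved, and only a compound such as the plain phenyl, the 3-methylphenyl or a chloropyridinyl ring on the same oxygen could separate them. Also open, from the compounds shown here alone, is whether chlorine must stand where it stands in 3-chlorophenyl, and whether a larger group there, such as methoxy or trifluoromethyl, would move the number in the same direction.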